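An Isopropyl Group Enters the Amino Acid Arm

The source may report more compounds than this note shows. Statements on the series, on what has been measured and on what is new or still open speak of the compounds shown alone.

Compound 1 `COC1=CC(=O)C(O)=C(C/C=C(\C)CC[C@@]2(C)CCC=C(C)[C@H]2C)C1=O` gives 2 ug/mL in an ADME assay on L1210 cells (Mus musculus) for cytotoxicity, with a stated time of 48 h; a higher number here means a weaker inhibitor, a lower number a stronger inhibitor.
Compound 2 `CC1=CCC[C@](C)(CC/C(C)=C/CC2=C(O)C(=O)C=C(NCC(=O)O)C2=O)[C@@H]1C` gives 3.5 ug/mL in this assay.

Going by the values given here, compound 2 is one of only two measured compounds, and its value lies within the scatter of compound 1, since the step of a 1.8-fold higher number from compound 1 to compound 2 (0.24 log units; within the scatter) does not exceed the usual spread. Compound 3 `CC1=CCC[C@](C)(CC/C(C)=C/CC2=C(O)C(=O)C=C(N[C@H](C(=O)O)C(C)C)C2=O)[C@@H]1C` differs from compound 2 by isopropyl in place of hydrogen on a saturated chain carbon bound to an amine nitrogen and a carbonyl carbon. Among the compounds with values here, no measured step touches this position, so the only guide is that the single known step stayed within the scatter. A change beyond the scatter in this assay is therefore not expected. For compound 3 the estimate is 3 ug/mL, with a range from 1 ug/mL to 9 ug/mL, an expected step of a 1.2-fold lower number from compound 2 to compound 3 (0.07 log units; within the scatter).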

Compound 3, half-maximal inhibitory concentration: 3.4 ug/mL
Estimate against measurement, compound 3: 1.1-fold (0.05 log units) below; the range from low to high includes it.
By their numbers in this assay, from the lowest: compounds 1, 3 and 2 (each within the scatter of the next).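

Isopropyl in place of hydrogen on this saturated chain carbon bound to an amine nitrogen and a carbonyl carbon gives a 1.0-fold lower number from compound 2 to compound 3 (0.01 log units; within the scatter) in this assay, the first measured change at this position. Exchanging methoxy for (1-carboxy-2-methylpropyl)amino gives a 1.7-fold higher number from compound 1 to compound 3 (0.23 log units; within the scatter) and likewise stays within the usual spread. Nothing measured here offers an explanation for these results.

As far as these compounds go, whether an amine or a longer chain on this same carbon would move the number beyond the scatter remains open.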